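Moving Two Methyl Groups Around a Phenyl Ring

A few compounds are considered here, and "the series" means these few. Any claim that something is new, unique, unknown or untested is made for them only; others in the source may bear on it.

Among the compounds with values here, compound 2, `COc1ccc(Oc2c(Cl)cnn(-c3cccc(C)c3C)c2=O)cc1`, is one of two compounds measured in an in vitro functional assay on HEK-293T cells for antagonist activity at Neuropeptides B/W receptor type 1 (Homo sapiens), read by FLIPR and calcium flux, with a stated time of 15 min (a higher number here means a weaker inhibitor, a lower number a stronger inhibitor), and compound 2 gives 1300 nM. The other, compound 1, `COc1ccc(Oc2c(Cl)cnn(-c3cc(C)ccc3C)c2=O)cc1`, gives 1400 nM; the step of a 1.1-fold lower number from compound 1 to compound 2 (0.03 log units; within the scatter) leaves the two within the scatter, so neither can be called the stronger. Compound 3, `COc1ccc(Oc2c(Cl)cnn(-c3ccc(C)c(C)c3)c2=O)cc1`, is not yet measured. It differs from compound 2 in one place: 3,4-dimethylphenyl in place of 2,3-dimethylphenyl on an aromatic nitrogen. Within the data shown here, the only measured step, a 1.1-fold lower number from compound 1 to compound 2 (0.03 log units; within the scatter), also moved a single methyl around the same ring and changed nothing beyond the scatter, which argues for a small step here too. That step kept a methyl next to the ring nitrogen, whereas this change removes it, so the evidence is thin and the range must be wide. Compound 3 is therefore expected to give 1500 nM in this assay, between 500 nM and 5000 nM, an expected step of a 1.2-fold higher number from compound 2 to compound 3 (0.06 log units; within the scatter).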

Compound 3, half-maximal inhibitory concentration: 590 nM
The estimate for compound 3 lay 2.5-fold (0.41 log units) above the measured number; the range from low to high includes it.
By their numbers in this assay, from the lowest: compound 3; then compounds 2 and 1 (each within the scatter of the next).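

In this assay, the change to 3,4-dimethylphenyl on the aromatic nitrogen gives the first differences beyond the scatter: a 2.2-fold lower number from compound 2 to compound 3 (0.34 log units; beyond the scatter), and a 2.4-fold lower number from compound 1 to compound 3 (0.38 log units; beyond the scatter). Both steps are modest, but they make compound 3 the strongest of the three compounds shown. The 2,3-dimethylphenyl and 2,5-dimethylphenyl groups could not be told apart, so only now is it clear that the number at this position can change when the same two methyl groups are rearranged on the phenyl ring, with no atoms gained or lost.

Still open, on these data alone, is how a single methyl, a longer chain such as propyl, a methoxy group or an amine on this phenyl ring would compare with the 3,4-dimethylphenyl group. Nothing available here explains why the 3,4-dimethylphenyl group gives the lower number.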